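The source may report more compounds than this note shows. Statements on the series, on what has been measured and on what is new or still open speak of the compounds shown alone.

Measured so far, in a functional assay (QGY7701 cells, Homo sapiens) for inhibition, read by MTT assay, with a stated time of 48 h; a lower number here means a stronger inhibitor, a higher number a weaker inhibitor:
compound 1 `COc1ccc2c(=O)c(/C=C/C(=O)Nc3cccc(C)c3)coc2c1` — > 100000 nM, a limit of the assay and not a number
compound 2 `COc1ccc2c(=O)c(/C=C/C(=O)NCc3ccc(C)cc3)coc2c1` — 10200 nM

Compound 2 holds the only number shown in this assay; the other value is a limit. The step of an at least 9.8-fold lower number from compound 1 to compound 2 (0.99 log units; beyond the scatter) is the only measured one, and it rests on a limit (the limit of > 100000 nM in this assay, at which 1 of the 2 values shown sits), so its true size is known only as a floor. Compound 3 `COc1ccc2c(=O)c(/C=C/C(=O)Nc3ccccc3C)coc2c1` differs from compound 2 by 2-methylphenyl in place of 4-methylbenzyl on an amide-type nitrogen. This reverses the direction of the measured step, which went from a methylphenyl amide to a methylbenzyl amide and was at least modest, while also relocating the methyl. The expectation for compound 3 is therefore a higher number than compound 2, a step of about a 5.9-fold higher number from compound 2 to compound 3 (0.77 log units; beyond the scatter), with a fair chance that this assay again returns only a limit. Compound 3 is estimated at 60000 nM, within 15000 nM to 150000 nM.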

Compound 3, half-maximal inhibitory concentration: 22500 nM
Beside the measured number, compound 3's estimate is 2.7-fold (0.43 log units) above it; low and high end bracket the measured number.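

In this assay, an amide bearing a methylphenyl group now gives a measured number, and a 2.2-fold higher number from compound 2 to compound 3 (0.34 log units; beyond the scatter) shows only a modest gap to the 4-methylbenzyl amide, so a phenyl directly on the amide-type nitrogen does not by itself take the series to the limit. The place of the methyl on that phenyl also matters, as 2-methylphenyl in place of 3-methylphenyl gives an at least 4.4-fold lower number from compound 1 to compound 3 (0.64 log units; beyond the scatter). The value of compound 1 is a limit of the assay and not a number, so this step is known only as a floor: the limit of > 100000 nM in this assay, at which 1 of the 3 values shown sits.

Compound 2 and compound 3 differ both in the benzyl carbon and in the methyl placement, which leaves the share of each in their gap unresolved. From the compounds shown here alone, it also remains open whether a phenethyl group on the amide-type nitrogen, or an amine or carboxylic acid on its ring, would give a lower number than compound 2.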